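Chloro for methoxy on the aryl ring of compound 1

The source may report more compounds than this note shows. Statements on the series, on what has been measured and on what is new or still open speak of the compounds shown alone.

Within the data shown here, compound 1 `COc1ccc(C2CC(c3ccc4ccccc4c3)=NN2C2=NC(=O)/C(=C3\C(=O)Nc4ccccc43)S2)cc1` gives 17500 nM in a functional assay on cells (Leukemia cell, Homo sapiens) for cytotoxicity, read by sulforhodamine B assay, with a stated time of 48 h (on this read-out higher numbers stand for weaker inhibition of growth and lower numbers for stronger inhibition of growth), the highest of the two numbers so far; compound 2 `COc1ccc(C2CC(c3ccc4ccccc4c3)=NN2C2=NC(=O)/C(=C3\C(=O)Nc4ccc(Br)cc43)S2)cc1` gives 130 nM in this assay. Among the measured compounds shown here, the only measured step, a 130-fold lower number from compound 1 to compound 2 (2.13 log units; beyond the scatter), is a bromo in place of hydrogen on an aromatic carbon and lies on a different part of the shared core. Compound 3 `O=C1N=C(N2N=C(c3ccc4ccccc4c3)CC2c2ccc(Cl)cc2)S/C1=C1/C(=O)Nc2ccccc21` differs from compound 1 by chloro in place of methoxy on an aromatic carbon. For the measured compounds named here, no measured step bears on this change, so the expected step is no change at the digits printed from compound 1 to compound 3 (within the scatter), nothing beyond the scatter. Compound 3 is estimated at 17500 nM, range 4000 nM to 70000 nM.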

Compound 3, concentration for 50% growth inhibition: 19100 nM
Estimate against measurement, compound 3: 1.1-fold (0.04 log units) below; the measured number falls inside the stated range.
By their numbers in this assay, from the lowest: compound 2; then compounds 1 and 3 (each within the scatter of the next).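

The change from 4-methoxyphenyl to 4-chlorophenyl gives a 1.1-fold higher number from compound 1 to compound 3 (0.04 log units; within the scatter) in this assay and so leaves the read-out unmoved at this position, on the core without bromo. Unlike a 130-fold lower number from compound 1 to compound 2 (2.13 log units; beyond the scatter) on another part of the core, this step gives no separation between the two compounds. No measured data on any property of these groups accompany this result.

An amine or a carboxylic acid at this position remains untested in the compounds shown. Going by these compounds, whether chloro for methoxy stays as silent with the bromo of compound 2 present also remains open.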